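Shortening the alkyl chain on a sulfonamide-bearing benzimidazole core

The source may report more compounds than this note shows. Statements on the series, on what has been measured and on what is new or still open speak of the compounds shown alone.

Measured compounds:
compound 1 `CCCCn1c(CCC)nc2cc(N)ccc21` gives 18200000 nM in a functional assay, read by spectrophotometry, in phosphate buffer, with a stated time of 20 min, at pH 6.6; a lower number here means that less compound is needed, a higher number that more compound is needed for the effect;
compound 2 `CCCCCn1c(CCC)nc2cc(NS(C)(=O)=O)ccc21` gives 3700000 nM in this assay;
compound 3 `CCCCCCn1c(CCC)nc2cc(NS(C)(=O)=O)ccc21` gives 5100000 nM in this assay.

Compound 3 has the second highest number of the three. Its nearest neighbour is compound 2, the two values lying within the scatter of each other, while compound 1 shows the highest number of all. Compound 4 `CCCCn1c(CCC)nc2cc(NS(C)(=O)=O)ccc21` differs from compound 3 by hydrogen in place of ethyl on a saturated chain carbon, four bonds along the chain from an aromatic nitrogen. Within the data shown here, the only step that bears on this is a 1.4-fold higher number from compound 2 to compound 3 (0.14 log units; within the scatter), which lengthened the same chain by one carbon and changed nothing beyond the scatter. Removing two carbons is therefore expected to move this assay little, giving an estimated step of a 1.1-fold lower number from compound 3 to compound 4 (0.05 log units; within the scatter). Compound 4 is estimated at 4500000 nM, with a range from 2000000 nM to 12000000 nM.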

Compound 4, half-maximal effective concentration: 4000000 nM
Beside the measured number, compound 4's estimate is 1.1-fold (0.05 log units) above it; low and high end bracket the measured number.
By their numbers in this assay, from the lowest: compounds 2, 4 and 3 (each within the scatter of the next); then compound 1.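

Replacing ethyl with hydrogen on this chain carbon gives a 1.3-fold lower number from compound 3 to compound 4 (0.11 log units; within the scatter) and replacing methyl with hydrogen gives a 1.1-fold higher number from compound 2 to compound 4 (0.03 log units; within the scatter) so in this assay all three chain lengths now lie within the scatter of each other. Among these compounds, compound 4 also gives the first one-place comparison for the sulfonamide: methylsulfonyl in place of hydrogen on a nitrogen on an aromatic ring gives a 4.6-fold lower number from compound 1 to compound 4 (0.66 log units; beyond the scatter) and this step lies beyond the scatter. Nothing available explains why the number moves with one change and not the other.

Going by these compounds, whether a much longer chain, or a chain carrying a carboxylic acid, would move the number remains open. So does whether acetyl could replace methylsulfonyl and keep the step.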